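Benzyl in place of (tert-butyl)carbamoyl: expecting compound 4

The source may report more compounds than this note shows. Statements on the series, on what has been measured and on what is new or still open speak of the compounds shown alone.

Measured so far in a physicochemical assay for solubility; on this read-out higher numbers stand for higher solubility and lower numbers for lower solubility:
- compound 1 `CN(C)CC(=O)N1CCC(NS(=O)(=O)c2cc(S(=O)(=O)c3ccccc3)ccc2C(F)(F)F)CC1` gives 100000 nM
- compound 2 `CN(C)CC(=O)N1CCC[C@H]1C(=O)N1CCC(NS(=O)(=O)c2cc(S(=O)(=O)c3ccccc3)ccc2C(F)(F)F)CC1` gives 100000 nM
- compound 3 `CC(C)(C)NC(=O)N1CCC[C@H]1C(=O)N1CCC(NS(=O)(=O)c2cc(S(=O)(=O)c3ccccc3)ccc2C(F)(F)F)CC1` gives 50000 nM

Compound 3 stands within the scatter of both other compounds, as a 2.0-fold lower number from compound 1 to compound 3 (0.30 log units; within the scatter) and a 2.0-fold lower number from compound 2 to compound 3 (0.30 log units; within the scatter) show. The next structure is compound 4 `O=C([C@@H]1CCCN1Cc1ccccc1)N1CCC(NS(=O)(=O)c2cc(S(=O)(=O)c3ccccc3)ccc2C(F)(F)F)CC1`. The change is benzyl in place of (tert-butyl)carbamoyl on an amine nitrogen in a ring, in words benzyl in place of (tert-butyl)carbamoyl on an amine nitrogen in a ring.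

For the measured compounds named here, no measured step makes this exact swap, and no measured compound carries a benzyl. The closest evidence is a 2.0-fold lower number from compound 2 to compound 3 (0.30 log units; within the scatter), where the group on that same ring nitrogen was exchanged. The larger addition in no change at the digits printed from compound 1 to compound 2 (within the scatter) also stayed within the scatter. On this thin basis, no step beyond the scatter is expected in this assay, though the uncertainty is wide. The estimated step is a 1.4-fold lower number from compound 3 to compound 4 (0.15 log units; within the scatter). Compound 4 is estimated at 35000 nM, with an expected range from 10000 nM to 100000 nM.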

Compound 4, solubility: 25000 nM
Compound 4: middle estimate off by 1.4-fold (0.15 log units), on the high side; the range from low to high includes it.
By their numbers in this assay, from the lowest: compounds 4, 3, 1 and 2 (each within the scatter of the next, the first and the last beyond it).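

In this assay, placing benzyl on the amine nitrogen of the five-membered ring instead of (tert-butyl)carbamoyl gives a 2.0-fold lower number from compound 3 to compound 4 (0.30 log units; within the scatter) and so cannot be told apart from the scatter, even though an all-carbon aromatic ring replaces a group with a hydrogen-bond donor and acceptor. For the compounds shown here, the comparison with ((dimethylamino)methyl)carbonyl on that same nitrogen gives a 4.0-fold lower number from compound 2 to compound 4 (0.60 log units; beyond the scatter) and the exchange of the whole 1-benzylpyrrolidin-2-yl for (dimethylamino)methyl gives a 4.0-fold lower number from compound 1 to compound 4 (0.60 log units; beyond the scatter), and these modest steps beyond the scatter are the first sign that this position can shift the read-out at all. Nothing measured here explains these steps.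

The compounds shown leave open how a carboxylic acid or a longer chain ending in an amine on this ring nitrogen would read in this assay. They also leave open whether a benzyl carrying a further group on its aromatic ring would read any differently.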